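Removing a Methyl Group on the Way to Compound 3

The source may hold more compounds than are shown below. What is called first, only, known or untested is meant among the compounds shown, and "the series" means these compounds.

Compound 1 `COc1cc(OC)c2sc(-c3ccc(N/C=C\C(=O)c4ccc(OC)c(F)c4)c(C)c3)nc2c1` was tested in a functional assay on A549 cells (Homo sapiens) for antiproliferative activity, read by sulforhodamine B assay, with a stated time of 48 h (on this read-out lower numbers stand for stronger inhibition and higher numbers for weaker inhibition), where compound 1 gives 15300 nM. Among the two measured compounds this is the highest number; the nearest is compound 2 `COc1cc(OC)c2sc(-c3ccc(N/C=C\C(=O)c4ccc(OC)c([N+](=O)[O-])c4)c(C)c3)nc2c1`, which in this assay gives 12100 nM. Among the compounds with values here, the only measured step, nitro in place of fluoro on an aromatic carbon, is a 1.3-fold lower number from compound 1 to compound 2 (0.10 log units; within the scatter), so the two values cannot be told apart.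

Compound 3 `COc1cc(OC)c2sc(-c3ccc(N/C=C\C(=O)c4ccc(OC)c(F)c4)cc3)nc2c1` has not yet been measured. Compared with compound 1 it differs as follows: hydrogen in place of methyl on an aromatic carbon. Within the data shown here, no measured step touches this part of the structure, and the one measured step concerns a different ring, so nothing known here points to a change in either direction. The expectation for compound 3 is therefore a number close to that of compound 1, with the step of a 1.0-fold lower number from compound 1 to compound 3 (0.01 log units; within the scatter) expected to stay within the scatter. Compound 3 is estimated at 15000 nM, with a range from 5000 nM to 45000 nM.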

Compound 3, half-maximal inhibitory concentration: 5300 nM
Compound 3: the middle estimate sits 2.8-fold (0.45 log units) above what was measured, within the range that was stated.
By their numbers in this assay, from the lowest: compound 3; then compounds 2 and 1 (each within the scatter of the next).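

In this assay, hydrogen in place of methyl gives a 2.9-fold lower number from compound 1 to compound 3 (0.46 log units; beyond the scatter), a modest step but one beyond the scatter. This shows that the aromatic carbon ortho to a large group and meta to a large group responds to a small change, whereas the earlier step on the other ring, a 1.3-fold lower number from compound 1 to compound 2 (0.10 log units; within the scatter), could not be told from the scatter. Here the methyl group is not needed for inhibition, and losing this single carbon goes with stronger inhibition, but nothing available explains the shift.

On these data alone, whether nitro in place of fluoro would still make no clear difference without the methyl group remains open. So does the effect of putting an ethyl group, a chlorine atom or an amine on this same carbon.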